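Piperidine to acyclic amine on the amide-bearing ring

The source may hold more compounds than are shown below. What is called first, only, known or untested is meant among the compounds shown, and "the series" means these compounds.

Two compounds of the series carry the same sulfamate-bearing core and an amide-linked aromatic ring. Compound 1 `NS(=O)(=O)Oc1ccc2c(c1)CN(C(=O)c1cccc(N3CCC(Cc4ccccc4)CC3)c1)CC2` in an assay on HEK293 cells for inhibition of Steryl-sulfatase (Homo sapiens), tested at 0.1 uM (on this read-out lower numbers stand for a weaker effect and higher numbers for a stronger effect at the one concentration tested), gives 1.4%. Compound 2 `NS(=O)(=O)Oc1ccc2c(c1)CN(C(=O)c1cccc(N3CCCCC3)c1)CC2` gives 1% and stands lowest of the two numbers, with compound 1 nearest and a number 0.4 percentage points lower from compound 1 to compound 2 (within the scatter). Compound 3 `CCN(Cc1ccc(F)cc1)c1cccc(C(=O)N2CCc3ccc(OS(N)(=O)=O)cc3C2)c1` is not yet measured. It differs from compound 2 by ethyl(4-fluorobenzyl)amino in place of piperidin-1-yl on an aromatic carbon. For the measured compounds named here, the only measured step, a number 0.4 percentage points lower from compound 1 to compound 2 (within the scatter), concerns a change on a saturated ring carbon and is within the scatter; no measured step touches the amine on the aromatic carbon itself. Both measured values lie close to the floor of the read-out, so compound 3 is expected to show a number 2 percentage points higher from compound 2 to compound 3 (within the scatter), a step without clear direction beyond the scatter. Compound 3 is therefore estimated at 3%, with a range from -8% to 15%.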

Compound 3, a percentage reported as inhibition, at one concentration (the size of the read-out at that concentration, not a potency): 10.9%
Estimate against measurement, compound 3: 7.9 percentage points below, within the range that was stated.
By their numbers in this assay, from the lowest: compounds 2, 1 and 3 (each within the scatter of the next).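

In this assay, for the compounds shown here, the replacement of piperidin-1-yl by ethyl(4-fluorobenzyl)amino is read as a number 9.9 percentage points higher from compound 2 to compound 3 (within the scatter) and is the first measured step at this position on an aromatic carbon, meta to a large group. At this one concentration, the position tolerates losing the six-membered non-aromatic ring and gaining a six-membered aromatic ring of carbon only, with no step beyond the scatter. No available measurement bears on the reason for this step.

Going by these compounds, it remains open whether the ethyl, the benzyl or the fluorine contributes to the step, as all three enter together. On these data alone, it is also open whether a smaller dimethylamino group or a carboxylic acid at this aromatic carbon would give a step beyond the scatter.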